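This account rests on a few compounds, and the source may have more. Where it says the series, first, only, none or still open, it means among the compounds named here.

Measured so far in an assay on CHO-K1 cells for antagonist activity at adenosine receptor A1 (Homo sapiens), read by a beta-galactosidase reporter, with stated times of 15 min and 6 h; on this read-out lower numbers stand for stronger inhibition and higher numbers for weaker inhibition:
compound 1 `CN(C)Cc1cc2c(N)nc(-c3ccco3)nc2s1` gives 3550 nM
compound 2 `Nc1nc(-c2ccco2)nc2sc(CN3CC=CCC3)cc12` gives 150 nM
compound 3 `Nc1nc(-c2ccco2)nc2sc(CN3CC=CC3)cc12` gives 290 nM

Compound 2 has the lowest number of the three. Its gap to compound 3 is within the scatter, a 1.9-fold higher number from compound 2 to compound 3 (0.29 log units; within the scatter), so the two cannot be ordered; the step from compound 1 is large, a 24-fold lower number from compound 1 to compound 2 (1.37 log units; beyond the scatter), as is a 12-fold lower number from compound 1 to compound 3 (1.09 log units; beyond the scatter).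

Compound 4 `Nc1nc(-c2ccc(Cl)o2)nc2sc(CN3CC=CCC3)cc12` differs from compound 2 by chloro in place of hydrogen on an aromatic carbon of the five-membered aromatic ring with one oxygen, next to the ring oxygen, two ring bonds from the ring atom that bears a large group; read one bond further out, furan-2-yl becomes 5-chlorofuran-2-yl.

Going by the values given here, none of the measured steps touches this place. All three concern the group on the saturated chain carbon bound to the aromatic carbon of the shared core, and the furan-2-yl is unchanged in compound 1, compound 2 and compound 3. The series therefore gives no direct reading on a chloro at the ring position; the working expectation is a step within the scatter in this assay, no change at the digits printed from compound 2 to compound 4 (within the scatter), with no direction preferred. Compound 4 is estimated at 150 nM, within 50 nM to 450 nM.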

Compound 4, inhibition constant: 190 nM
Estimate against measurement, compound 4: 1.3-fold (0.10 log units) below; the measured number falls inside the stated range.
By their numbers in this assay, from the lowest: compounds 2, 4 and 3 (each within the scatter of the next); then compound 1.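

Going by these compounds alone, the exchange of furan-2-yl for 5-chlorofuran-2-yl gives the first reading at this position in this assay: a 1.3-fold higher number from compound 2 to compound 4 (0.10 log units; within the scatter), so the two compounds cannot be ordered. Within the data shown here, on this single pair, a chloro on this carbon of the furan leaves the number within the scatter of the hydrogen compound, whereas the earlier steps all concerned the group on the saturated chain carbon. Nothing measured here accounts for this result.

Open, on these data alone, is whether a larger or different group at this position, such as bromo, methyl, methoxy, an amine or a carboxylic acid, would also stay within the scatter. Also open, as far as these compounds go, is whether chloro reads the same when the chain carbon carries the groups of compound 1 or compound 3.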